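This account rests on a few compounds, and the source may have more. Where it says the series, first, only, none or still open, it means among the compounds named here.

Compound 1 `CS(=O)(=O)c1ccc(-c2cnc(N)c(-c3ccc(N)nc3)n2)cc1` and compound 2 `Nc1ncc(-c2ccc(C(=O)N3CCC(O)CC3)cc2)nc1-c1ccc(C(F)(F)F)cc1` have been run in an ADME assay on microsomes from liver (Rattus norvegicus) for metabolic stability, read by LC-MS, using NADPH, with a stated time of 30 min, tested at 0.1 uM, in the presence of a further agent that is not named here; on this read-out higher numbers stand for a more stable compound and lower numbers for a less stable compound. Compound 1 reaches the limit of the assay, > 90%, so only a limit and no number stands for it. Compound 2 likewise sits at the limit, > 90%, again a limit rather than a number. Where compound 2 stands is therefore known only as a limit, and the one further value shown is a limit too; both values sit together at the same point (the limit of > 90% in this assay, at which 2 of the 2 values shown sit). Within the data shown here, no step between measured compounds is available, so no measured change sets a scale. Compound 3 `Nc1ncc(-c2ccc(C(=O)N3CC(O)C3)cc2)nc1-c1ccc(C(F)(F)F)cc1` differs from compound 2 in one place: 3-hydroxyazetidin-1-yl in place of 4-hydroxypiperidin-1-yl on a carbonyl carbon. The change keeps one hydrogen-bond donor and one hydrogen-bond acceptor and removes two heavy atoms. The step from compound 2 to compound 3 is expected to be small, a number no higher from compound 2 to compound 3 (the limit leaves the size open), not beyond the scatter in this assay. Compound 3 is estimated in this assay at 90%, within 72% to 99%.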

Compound 3, percent of the compound remaining: > 90%
Compound 3: a limit, no number; the forecaster's own chance of this, stated with the estimate: 65%; the middle value sits exactly at the limit.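

In this assay no step can be read between compound 2 and compound 3, as each stands at a limit and not at a number. The compounds shown leave open how they differ, if at all, past the one point where they all sit: the limit of > 90% in this assay, at which 3 of the 3 values shown sit.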